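Cytotoxicity Limits Carried from Furan to Ethoxyphenyl

The compounds below may be only part of what the source reports. "The series", "measured", "known", "first", "only" and "open" are said of these compounds alone.

The shared core is seen in compound 1 `CCOC(=O)CCCCCOc1cccc(CN(C(=O)c2ccc(-c3cccc4ccccc34)cc2)C(C)C)c1`, which carries naphthalen-1-yl on an aromatic carbon. In an ADME assay on BJ cells (Homo sapiens) for cytotoxicity, read by CellTiter-Glo and resazurin assay, with a stated time of 72 h (a higher number here means that more compound is needed for the effect, a lower number that less compound is needed), compound 1 reaches only the limit of the assay, > 26000 nM. Compound 2 `CCOC(=O)CCCCCOc1cccc(CN(C(=O)c2ccc(-c3ccco3)cc2)C(C)C)c1` has furan-2-yl in place of naphthalen-1-yl on an aromatic carbon. In this assay compound 2 likewise stops at the limit, > 26000 nM. The step that the two limits leave unreadable from compound 1 to compound 2 cannot be read: both of its ends are limits. Where compound 2 stands is therefore known only as a limit, and the one further value shown is a limit too (the limit of > 26000 nM in this assay, at which 2 of the 2 values shown sit).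

Compound 3 `CCOC(=O)CCCCCOc1cccc(CN(C(=O)c2ccc(-c3cccc(OCC)c3)cc2)C(C)C)c1` differs from compound 2 by 3-ethoxyphenyl in place of furan-2-yl on an aromatic carbon. Within the data shown here, the only measured step touching this position, a step that the two limits leave unreadable from compound 1 to compound 2, has no readable size, so no direction beyond the scatter can be drawn from it for this assay. Compound 2 sits at the limit > 26000 nM. Compound 3 is therefore expected to stay near that limit, the step that the limit leaves unreadable from compound 2 to compound 3 being estimated as small. In this assay compound 3 is expected to give about 30000 nM, in a range from 15000 nM to 80000 nM.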

Compound 3, half-maximal effective concentration: > 22300 nM
Compound 3: no number, only a limit; the forecaster's own chance of this, stated with the estimate: 75%; the middle value does not contradict the limit.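

In this assay compound 3 also reaches only a limit of the assay, > 22300 nM. Among these compounds, no new step can therefore be read among compound 1, compound 2 and compound 3. The compounds shown leave open the concentration at which any of the three reaches its half-maximal effect, and whether exchanging the group at this position changes it.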